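Nitrofuran amide series: cytotoxicity on Vero cells

This account rests on a few compounds, and the source may have more. Where it says the series, first, only, none or still open, it means among the compounds named here.

Measured so far in an ADME assay on Vero cells (Chlorocebus sabaeus) for cytotoxicity, read by MTT assay, with a stated time of 72 h; on this read-out lower numbers stand for stronger inhibition and higher numbers for weaker inhibition:
compound 1, `COc1cccc(-c2csc(NC(=O)c3ccc([N+](=O)[O-])o3)n2)c1`, gives 58700 nM
compound 2, `COc1ccccc1-c1csc(NC(=O)c2ccc([N+](=O)[O-])o2)n1`, gives 42000 nM

Compound 2 holds the lowest of the two numbers; its nearest neighbour is compound 1, and the step of a 1.4-fold lower number from compound 1 to compound 2 (0.15 log units; within the scatter) is within the scatter, so the two compounds cannot be ranked on this assay. Compound 3, `O=C(Nc1nc(-c2cccc(Cl)c2)cs1)c1ccc([N+](=O)[O-])o1`, differs from compound 2 by 3-chlorophenyl in place of 2-methoxyphenyl on an aromatic carbon. Among the compounds with values here, the only measured step, a 1.4-fold lower number from compound 1 to compound 2 (0.15 log units; within the scatter), moves a methoxy group around the same phenyl ring and changes nothing beyond the scatter; no measured pair exchanges a methoxy for a chlorine, so nothing bears directly on this change. With both numbers so close, a step within the scatter is expected in this assay, with no direction. Compound 3 is therefore estimated at 45000 nM, with a range of 15000 nM to 135000 nM, which means an expected step of a 1.1-fold higher number from compound 2 to compound 3 (0.03 log units; within the scatter).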

Compound 3, half-maximal inhibitory concentration: 43700 nM
The estimate for compound 3 lay 1.0-fold (0.01 log units) above the measured number, and the stated range covers the measured number.
By their numbers in this assay, from the lowest: compounds 2, 3 and 1 (each within the scatter of the next).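

Chloro in place of methoxy on the phenyl ring gives a 1.3-fold lower number from compound 1 to compound 3 (0.13 log units; within the scatter), and 3-chlorophenyl in place of 2-methoxyphenyl gives a 1.0-fold higher number from compound 2 to compound 3 (0.02 log units; within the scatter); the earlier compounds showed only a methoxy group moved around the ring. In this assay, a change of the group itself on this aromatic carbon, with hydrogen-bond acceptors going from 1 to 0 in the entering group, therefore also stays within the scatter. Nothing on hand accounts for this lack of separation.

All the compounds shown carry a phenyl ring with a single methoxy or chloro group at this place, so it remains open whether any change here gives a step beyond the scatter. An amine or a carboxylic acid on that ring, or a longer chain in place of the phenyl, would test this in this assay.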